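This account rests on a few compounds, and the source may have more. Where it says the series, first, only, none or still open, it means among the compounds named here.

Working notes on the series. Within the data shown here, compound 3 `Cc1c(C(=O)Nc2c(F)cc(-c3cccc(F)c3)cc2F)nc2ccc(OC(F)(F)F)cc2c1O` carries the highest number of the three measured so far in a functional assay on Hep 3B2 cells (Homo sapiens) for antiproliferative activity, read by MTT assay, with a stated time of 24 h, tested at 11.11 ug/mL; a lower number here means a weaker effect, a higher number a stronger effect of the compound at the concentration tested: compound 3 gives 37.9%. Compound 2 `Cc1c(C(=O)Nc2c(F)cc(-c3cccc(F)c3)cc2F)nc2ccc(F)cc2c1O` is nearest; in this assay compound 2 gives 31.3%, and the step is a number 6.6 percentage points higher from compound 2 to compound 3 (within the scatter). Compound 1 `Cc1ccc2nc(C(=O)Nc3c(F)cc(-c4cccc(F)c4)cc3F)c(C)c(O)c2c1` is furthest; in this assay compound 1 gives 25.5%, and the step is a number 12.4 percentage points higher from compound 1 to compound 3 (beyond the scatter). The remaining step is a number 5.8 percentage points higher from compound 1 to compound 2 (within the scatter). All three compounds differ only in the group on one aromatic carbon of a six-membered aromatic ring of carbon only, part of a fused or bridged system of two rings.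

Compound 4 `Cc1c(C(=O)Nc2c(F)cc(-c3cccc(F)c3)cc2F)nc2ccc(C(F)(F)F)cc2c1O` awaits measurement. The change is trifluoromethyl in place of trifluoromethoxy on an aromatic carbon. The measured steps bear on it only indirectly: each exchanged one group at this carbon for another, and only the exchange of methyl for trifluoromethoxy moved the number beyond the scatter. Among the measured compounds shown here, no measured step exchanges trifluoromethoxy for trifluoromethyl, so the expectation rests on the three groups tried at this carbon spreading the number over a modest range, with trifluoromethoxy at the top. The expected step is a number 1.9 percentage points lower from compound 3 to compound 4 (within the scatter), none beyond the scatter. Compound 4 is expected to give about 36% in this assay, with a range from 26% to 46%.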

Compound 4, a percentage reported as inhibition, at one concentration (the size of the read-out at that concentration, not a potency): 36.3%
The estimate for compound 4 lay 0.3 percentage points below the measured number; the measured number falls inside the stated range.
By their numbers in this assay, from the lowest: compounds 1, 2, 4 and 3 (each within the scatter of the next, the first and the last beyond it).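

At this aromatic carbon, in this assay, trifluoromethyl in place of trifluoromethoxy gives a number 1.6 percentage points lower from compound 3 to compound 4 (within the scatter) and so removes the oxygen of the trifluoromethoxy group without a change beyond the scatter. Compound 1, with methyl, now stands apart from two compounds rather than one, since a number 10.8 percentage points higher from compound 1 to compound 4 (beyond the scatter) is a second step beyond the scatter alongside a number 12.4 percentage points higher from compound 1 to compound 3 (beyond the scatter) in the same direction, while the fluoro of compound 2 still cannot be separated from the groups above it, as a number 5 percentage points higher from compound 2 to compound 4 (within the scatter) shows, or from methyl. Nothing on hand gives a cause for these steps.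

The four groups compared here leave open how an amine, a carboxylic acid, a nitrile or a longer chain such as butyl at this carbon would read, and whether the number can be taken well outside this modest range by any change at this position. Each figure is also a single inhibition read-out at one concentration, so the series gives no potency, and compounds that read alike here might still differ at other concentrations.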